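Shortening an Ethoxy Group to Methoxy on Compound 2

This account rests on a few compounds, and the source may have more. Where it says the series, first, only, none or still open, it means among the compounds named here.

Compound 1 `Cc1c(C(=O)Nc2c(F)cc(-c3cccc(F)c3)cc2F)nc2ccc(F)cc2c1C(=O)O` and compound 2 `CCOc1ccc2nc(C(=O)Nc3c(F)cc(-c4cccc(F)c4)cc3F)c(C)c(C(=O)O)c2c1` share a core and differ only at one aromatic carbon. In a functional assay on Hep 3B2 cells (Homo sapiens) for antiproliferative activity, read by MTT assay, with a stated time of 24 h, tested at 3.7 ug/mL (on this read-out higher numbers stand for a stronger effect at the one concentration tested and lower numbers for a weaker effect), compound 1 gives 11.2%, while compound 2 gives 26.5%; the step of a number 15.3 percentage points higher from compound 1 to compound 2 (beyond the scatter) is the only one measured, and it leaves compound 2 with the higher of the two numbers. Compound 3 `COc1ccc2nc(C(=O)Nc3c(F)cc(-c4cccc(F)c4)cc3F)c(C)c(C(=O)O)c2c1` differs from compound 2 by hydrogen in place of methyl on a saturated chain carbon bound to an oxygen on an aromatic ring. Among the compounds with values here, no measured step trims an ethoxy to a methoxy, so the expectation is a small decline or none beyond the scatter, estimated as a number 6.5 percentage points lower from compound 2 to compound 3 (within the scatter). Compound 3 is therefore expected to give about 20%, within 8% to 33%.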

Compound 3, a percentage reported as inhibition, at one concentration (the size of the read-out at that concentration, not a potency): 1.62%
Compound 3: middle estimate off by 18.4 percentage points, on the high side; the measured number lies below the stated range.
By their numbers in this assay, from the lowest: compounds 3 and 1 (each within the scatter of the next); then compound 2.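

Trimming the ethoxy group by a single methyl has a sizeable effect: the result is a number 24.9 percentage points lower from compound 2 to compound 3 (beyond the scatter). The gain seen with ethoxy therefore does not carry over to the shorter methoxy group. Methoxy in place of fluoro gives a number 9.6 percentage points lower from compound 1 to compound 3 (within the scatter), so these two groups cannot be told apart at this aromatic carbon. Nothing available here offers a reason for the drop. Going by these compounds, whether a longer chain such as propoxy, or an amine, at this carbon would keep or raise the number remains open.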